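Compound 4: a lactam replacing the oxazole amine

The compounds below may be only part of what the source reports. "The series", "measured", "known", "first", "only" and "open" are said of these compounds alone.

Within the data shown here, compound 1 `CN(c1ncco1)c1cnc(NCc2c(F)ccc3c2CCO3)n2cnnc12` gives 2.1 in a physicochemical assay for lipophilicity, using the shake flask method, in phosphate buffer, measured as octanol-water partition, with a stated time of 30 min, at pH 7.4 (a higher number here means a more lipophilic compound, a lower number a more polar compound), the lowest of the three numbers measured so far. Compound 2 `Cc1cc(-c2cnc(NCc3c(F)ccc4c3CCO4)c3cn[nH]c(=O)c23)n(C)n1` gives 3 and compound 3 `Cc1ncccc1-c1cnc(NCc2c(F)ccc3c2CCO3)c2cn[nH]c(=O)c12` gives 3, each sitting above compound 1 by a gap beyond the scatter. Among the measured compounds shown here, the single measured step, no change at the digits printed from compound 2 to compound 3 (within the scatter), lies on a different core from compound 1 and does not bear on the change to compound 4 `C[C@H]1CC(=O)N(c2cnc(NCc3c(F)ccc4c3CCO4)n3cnnc23)C1`: 4-methyl-2-oxopyrrolidin-1-yl in place of methyl(1,3-oxazol-2-yl)amino on an aromatic carbon. For the measured compounds named here, no measured step covers this exchange, so the expected step of a number 0.20 log units lower from compound 1 to compound 4 (within the scatter) is small, possibly downward, and may well stay within the scatter. Compound 4 is therefore estimated at 1.9, with a range of 1.3 to 2.5.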

Compound 4, distribution coefficient: 1.8
Beside the measured number, compound 4's estimate is 0.10 log units above it; the measured number falls inside the stated range.
By their numbers in this assay, from the lowest: compounds 4 and 1 (each within the scatter of the next); then compounds 2 and 3 (each within the scatter of the next).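

Among these compounds, this is the first step read at this position on the core of compound 1: in this assay, the exchange gives a number 0.30 log units lower from compound 1 to compound 4 (within the scatter). At this aromatic carbon, a non-aromatic lactam ring carrying one defined stereocentre and an aromatic oxazole amine are therefore not separated by this read-out, despite their different hydrogen-bond acceptor counts. The position thus tolerates this change of ring type without a shift beyond the scatter.

As far as these compounds go, whether a carboxylic acid or a primary amine at this carbon would separate from compound 1 remains open. The data shown give no cause for the match between the two groups.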